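This account rests on a few compounds, and the source may have more. Where it says the series, first, only, none or still open, it means among the compounds named here.

Measured so far in an assay on HEK293 cells for displacement of a labelled ligand from 5-hydroxytryptamine receptor 7 (Rattus norvegicus), read by radioligand binding; a higher number here means a weaker inhibitor, a lower number a stronger inhibitor:
compound 1 `CC(C)n1nc2c(c1-c1ccc(Cl)cc1)CCNCC2` gives 9 nM
compound 2 `CC(C)n1nc2c(c1-c1ccc(C#N)cc1)CCNCC2` gives 90 nM

Within the data shown here, compound 2 holds the higher of the two numbers in this assay; its only neighbour is compound 1, and the step of a 10-fold higher number from compound 1 to compound 2 (1.00 log units; beyond the scatter) lies beyond the scatter. Compound 3 `CC(C)n1nc2c(c1-c1ccc(OC(F)(F)F)cc1)CCNCC2` carries trifluoromethoxy in place of cyano on an aromatic carbon. Among the measured compounds shown here, no measured step covers this exact exchange; only the step of a 10-fold higher number from compound 1 to compound 2 (1.00 log units; beyond the scatter) touches the same aromatic carbon. Compound 3 is therefore expected to sit somewhat below compound 2, an expected step of a 3.0-fold lower number from compound 2 to compound 3 (0.48 log units; beyond the scatter). Compound 3 is estimated at 30 nM, with a range from 8 nM to 120 nM.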

Compound 3, inhibition constant: 5000 nM
Compound 3: the middle estimate sits 170-fold (2.22 log units) below what was measured; measured number above the stated range.
By their numbers in this assay, from the lowest: compound 1; then compound 2; then compound 3.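

In this assay the aromatic carbon that carries these groups proves far more demanding than the earlier pair showed: trifluoromethoxy brings a 56-fold higher number from compound 2 to compound 3 (1.74 log units; beyond the scatter) and also a 560-fold higher number from compound 1 to compound 3 (2.74 log units; beyond the scatter) for the same position. Among these compounds, the exchange therefore moves this number much further than the single step known before, and chloro remains the best of the three groups. Nothing available here bears on what lies behind this loss.

From the compounds shown here alone, what methyl, methoxy or fluoro would give on this aromatic carbon stays open. So does whether trifluoromethyl, which lacks the oxygen of trifluoromethoxy, falls near compound 3 or nearer compound 1.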